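The source may report more compounds than this note shows. Statements on the series, on what has been measured and on what is new or still open speak of the compounds shown alone.

Of the compounds shown here, three that share one core have been measured in a physicochemical assay for lipophilicity, read by HPLC, measured as chromatographic lipophilicity, at pH 7.4; on this read-out higher numbers stand for higher lipophilicity and lower numbers for lower lipophilicity. Compound 1 (`O=C(c1ccccc1)N1CCC(C(=O)N2N=CCC2c2ccccc2)CC1`) gives 4.4, compound 2 (`O=C(c1cn[nH]c1)N1CCC(C(=O)N2N=CCC2c2ccccc2)CC1`) gives 2.1, and compound 3 (`O=C(C1CCN(c2ccccc2)CC1)N1N=CCC1c1ccccc1`) gives 6.3, the highest of the three numbers. Compound 4 (`O=C(C1CCCCC1)N1CCC(C(=O)N2N=CCC2c2ccccc2)CC1`) has not been measured yet. It differs from compound 3 as follows: cyclohexylcarbonyl in place of phenyl on an amine nitrogen in a ring. In short, cyclohexylcarbonyl stands in place of phenyl on an amine nitrogen in a ring.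

Two measured steps made the opposite kind of swap, putting phenyl on that nitrogen. The step of a number 1.90 log units higher from compound 1 to compound 3 (beyond the scatter) replaced benzoyl, and the step of a number 4.20 log units higher from compound 2 to compound 3 (beyond the scatter) replaced (1H-pyrazol-4-yl)carbonyl. Both are large, so a large drop is expected on going the other way. The step of a number 2.30 log units lower from compound 1 to compound 2 (beyond the scatter) shows that the group on the carbonyl also matters, so the size of the drop is uncertain. Compound 1, at 4.4, carries benzoyl, the closest measured match to cyclohexylcarbonyl, so the expectation stays near that value.

The expected change is a number 1.60 log units lower from compound 3 to compound 4 (beyond the scatter). For compound 4 the estimate is 4.7, within an expected range of 4.1 to 5.3.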

Compound 4, distribution coefficient: 5.4
The estimate for compound 4 lay 0.70 log units below the measured number, outside the stated range (above it).
By their numbers in this assay, from the lowest: compound 2; then compound 1; then compound 4; then compound 3.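

In this assay, a carbonyl group on the amine nitrogen in a ring need not bring the number far down: there is a number 0.90 log units lower from compound 3 to compound 4 (beyond the scatter) when cyclohexylcarbonyl stands in place of phenyl, a modest step. With the carbonyl kept, the ring attached to it makes a clear difference, with a number 1.00 log units higher from compound 1 to compound 4 (beyond the scatter) for cyclohexyl in place of phenyl and a number 3.30 log units higher from compound 2 to compound 4 (beyond the scatter) for cyclohexyl in place of 1H-pyrazol-4-yl. No evidence is available to explain these steps.

Because cyclohexylcarbonyl differs from phenyl in both its ring and its carbonyl, the step from phenyl does not separate the two, and cyclohexyl placed directly on that nitrogen would be needed to do so. On these data alone, how an open butyl chain, or a cyclohexyl ring carrying an amine or a carboxylic acid, would behave on that carbonyl also remains open.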